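Swapping the aryl group on the imide carbonyl

A few compounds are considered here, and "the series" means these few. Any claim that something is new, unique, unknown or untested is made for them only; others in the source may bear on it.

Three analogues share one core. Compound 1 `CN(C(=O)NC(=O)c1c(F)cccc1F)c1nc(C(F)(F)F)c(C(=O)N/N=C/c2cccc(C(F)(F)F)c2)s1` gives 27.6 ug/mL in a functional assay on A549 cells (Homo sapiens) for inhibition, read by MTT assay, with a stated time of 72 h; on this read-out higher numbers stand for weaker inhibition and lower numbers for stronger inhibition; compound 2 `CN(C(=O)NC(=O)c1ccc(F)c(F)c1)c1nc(C(F)(F)F)c(C(=O)N/N=C/c2ccccc2C(F)(F)F)s1` gives 6.96 ug/mL; compound 3 `CN(C(=O)NC(=O)c1ccc(C(F)(F)F)cc1)c1nc(C(F)(F)F)c(C(=O)N/N=C/c2cccc(C(F)(F)F)c2)s1` gives 6.66 ug/mL. Compound 3 sits at the low end, with the number of compound 2 within the scatter of it, while the step of a 4.1-fold lower number from compound 1 to compound 3 (0.62 log units; beyond the scatter) is clearly beyond the scatter. Compound 4 `CN(C(=O)NC(=O)c1ccc(F)c(F)c1)c1nc(C(F)(F)F)c(C(=O)N/N=C/c2cccc(C(F)(F)F)c2)s1` differs from compound 3 by 3,4-difluorophenyl in place of 4-(trifluoromethyl)phenyl on a carbonyl carbon. Going by the values given here, the one step that bears on this exchanges the aryl group at the same place in the other direction, and compound 2 carries this same 3,4-difluorophenyl group with a number close to that of compound 3, so compound 4 is expected to show a 1.4-fold higher number from compound 3 to compound 4 (0.15 log units; within the scatter), at most a small rise. The estimate for compound 4 is 9.5 ug/mL, within 4 ug/mL to 24 ug/mL.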

Compound 4, half-maximal inhibitory concentration: 6.52 ug/mL
Compound 4: middle estimate off by 1.5-fold (0.16 log units), on the high side, and the stated range covers the measured number.
By their numbers in this assay, from the lowest: compounds 4, 3 and 2 (each within the scatter of the next); then compound 1.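

With a 1.0-fold lower number from compound 3 to compound 4 (0.01 log units; within the scatter) on a carbonyl carbon, 3,4-difluorophenyl and 4-(trifluoromethyl)phenyl cannot be told apart here, and a 4.2-fold lower number from compound 1 to compound 4 (0.63 log units; beyond the scatter) shows that 3,4-difluorophenyl, unlike 2,6-difluorophenyl, keeps the number low. The other aryl group gives a similar picture: a 1.1-fold lower number from compound 2 to compound 4 (0.03 log units; within the scatter) comes with 3-(trifluoromethyl)phenyl in place of 2-(trifluoromethyl)phenyl on a carbon with a double bond to nitrogen. Nothing available explains these results. Going by these compounds, whether a plain phenyl, or an aryl group carrying an amine or a carboxylic acid, would give a similar number remains open.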